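This account rests on a few compounds, and the source may have more. Where it says the series, first, only, none or still open, it means among the compounds named here.

Measured in an ADME assay for permeability, using PAMPA, with a stated time of 30 min, at pH 7.4; a lower number here means that the compound crosses the layer more slowly, a higher number that the compound crosses the layer faster:
- compound 1 `FC(F)(F)c1ccc(-c2ccc3c(NCCCNCc4ccco4)ccnc3c2)cc1` gives 237 10^-6 cm/s
- compound 2 `COc1ccccc1Oc1ccc2c(NCCCNCc3ccco3)ccnc2c1` gives 317 10^-6 cm/s

Compound 2 holds the higher of the two numbers in this assay, though its nearest neighbour, compound 1, sits close: the step of a 1.3-fold higher number from compound 1 to compound 2 (0.13 log units; within the scatter) is within the scatter, so the two are not distinguishable.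

Compound 3 `COc1ccccc1Oc1ccc2c(NCCCNCc3cccc(OC)c3O)ccnc2c1` has not been measured. It differs from compound 2 in one place: 2-hydroxy-3-methoxyphenyl in place of furan-2-yl on a saturated chain carbon bound to an amine nitrogen. Within the data shown here, the only measured step, from compound 1 to compound 2, changes a group on an aromatic carbon of the shared core, not the chain end, so it does not bear on this change; there is no measured pair that does.

With nothing to point either way, the expectation for compound 3 rests on compound 2 alone, and the estimated step of a 1.4-fold lower number from compound 2 to compound 3 (0.16 log units; within the scatter) is not expected to clear the scatter. Compound 3 is therefore expected to give about 220 10^-6 cm/s in this assay, in a range from 110 10^-6 cm/s to 400 10^-6 cm/s.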

Compound 3, apparent permeability: 317 10^-6 cm/s
For compound 3 the middle estimate is 1.4-fold (0.16 log units) below the measured one; low and high end bracket the measured number.
By their numbers in this assay, from the lowest: compounds 1, 2 and 3 (each within the scatter of the next).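

Among these compounds, this is the first measured change at the chain end, on a saturated chain carbon bound to an amine nitrogen, and it is not a small one: furan-2-yl, a five-membered aromatic ring of 5 heavy atoms with no hydrogen-bond donor, gives way to 2-hydroxy-3-methoxyphenyl, a six-membered aromatic ring of 9 heavy atoms with 1 hydrogen-bond donor. In this assay the result reads no change at the digits printed from compound 2 to compound 3 (within the scatter) and the two compounds cannot be told apart, so this exchange leaves the read-out where it was. No measurement is at hand that would explain this.

Still open, from the compounds shown here alone, is whether the same holds for a carboxylic acid or an amine at this place, or for a longer chain. Also open, going by these compounds, is whether the exchange would read the same with 4-(trifluoromethyl)phenyl on the shared core, as in compound 1.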